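The source may hold more compounds than are shown below. What is called first, only, known or untested is meant among the compounds shown, and "the series" means these compounds.

Measured in an ADME assay on HepG2 cells (Homo sapiens) for inhibition, read by fluorescence and resazurin assay, with a stated time of 72 h; a higher number here means a weaker inhibitor, a lower number a stronger inhibitor:
compound 1 `Cc1ccc(Nc2nccc(Nc3ccc4nc[nH]c4c3)n2)cc1` — > 25000 nM, which is a limit of this assay and not a number.
compound 2 `Cc1cccc(Nc2nccc(Nc3ccc4nc[nH]c4c3)n2)c1` — 20000 nM.

Compound 1 stands only at a limit in this assay; no number is known for it. The step of an at least 1.2-fold lower number from compound 1 to compound 2 (0.09 log units; that floor lies within the scatter) lies within the scatter, so compounds 1 and 2 cannot be separated on these values. Compound 3 `CN1CCN(c2ccc(Nc3nccc(Nc4ccc5nc[nH]c5c4)n3)cc2)CC1` has not been measured in this assay. It differs from compound 1 by 4-methylpiperazin-1-yl in place of methyl on an aromatic carbon. Within the data shown here, no measured step concerns this change: the one step recorded, an at least 1.2-fold lower number from compound 1 to compound 2 (0.09 log units; that floor lies within the scatter), moves the methyl within the same ring and stays within the scatter, and it says nothing about a 4-methylpiperazin-1-yl group. The step of an at least 1.2-fold lower number from compound 1 to compound 3 (0.09 log units; that floor lies within the scatter) is therefore an expectation without a measured precedent and is set close to no change, with wide uncertainty in both directions. Because compound 1 sits at the limit of > 25000 nM in this assay, at which 1 of the 2 values shown sits, the chance that compound 3 also returns only a limit is considerable. Compound 3 is expected to give 20000 nM, within 8000 nM to 50000 nM.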

Compound 3, half-maximal inhibitory concentration: > 25000 nM
Compound 3 gave a limit, no number; the forecaster's own chance of this, stated with the estimate: 45%; at least 1.2-fold (0.09 log units) between middle value and limit.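

In this assay, compound 1 and compound 3 both stand only at a limit and not at a number, so no step between them can be read: the limit of > 25000 nM in this assay, at which 2 of the 3 values shown sit.

The compounds shown leave open whether 4-methylpiperazin-1-yl in place of methyl on an aromatic carbon changes the inhibition at all, and in which direction.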